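A few compounds are considered here, and "the series" means these few. Any claim that something is new, unique, unknown or untested is made for them only; others in the source may bear on it.

Within the data shown here, compound 2 `Clc1cccc(-c2nc(N3CCCCC3)c3nc[nH]c3n2)c1` gives 1000 nM in an assay on cells for displacement of a labelled ligand from adenosine receptor A2b (Homo sapiens), read by scintillation counting and radioligand binding, with a stated time of 30 min (on this read-out lower numbers stand for stronger inhibition and higher numbers for weaker inhibition), the higher of the two numbers measured so far; the other is compound 1 `Oc1cccc(-c2nc(N3CCCCC3)c3nc[nH]c3n2)c1` at 158 nM. Among the measured compounds shown here, the only measured step is a 6.3-fold higher number from compound 1 to compound 2 (0.80 log units; beyond the scatter), so the series offers one reading of the hydroxy-versus-chloro swap on the pendant ring and nothing else. Compound 3 `Oc1ccc(-c2nc(N3CCCCC3)c3nc[nH]c3n2)cc1` differs from compound 2 by 4-hydroxyphenyl in place of 3-chlorophenyl on an aromatic carbon. For the measured compounds named here, this reverses the chloro-for-hydroxy change but places the hydroxy group differently on the ring, and no measured compound carries a 4-hydroxyphenyl group, so the size of the return cannot be read off directly. The hydroxy-bearing compound 1 at 158 nM is the closest guide, and a lower number than compound 2 is expected in this assay, about a 5.0-fold lower number from compound 2 to compound 3 (0.70 log units; beyond the scatter). Compound 3 is therefore estimated at 200 nM, with a range of 60 nM to 700 nM.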

Compound 3, inhibition constant: 79.4 nM
Compound 3: middle estimate off by 2.5-fold (0.40 log units), on the high side; the range from low to high includes it.
By their numbers in this assay, from the lowest: compounds 3 and 1 (each within the scatter of the next); then compound 2.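

In this assay, 4-hydroxyphenyl in place of 3-chlorophenyl gives a 13-fold lower number from compound 2 to compound 3 (1.10 log units; beyond the scatter), a large step that shows this aromatic carbon of the shared core tolerates a wide spread of numbers depending on the pendant ring. Shifting the hydroxy group from 3-hydroxyphenyl to 4-hydroxyphenyl gives a 2.0-fold lower number from compound 1 to compound 3 (0.30 log units; within the scatter), so the two hydroxy placements cannot be told apart on this read-out. Both hydroxy compounds now sit clearly apart from the single chloro compound, with no compound shown going against that split, although it rests on only these three compounds.

Still open, going by these compounds, is whether the chloro effect depends on its ring place, as 4-chlorophenyl would show, and how unsubstituted phenyl, a methoxy group, an amine or a carboxylic acid would read at this ring. Nothing in hand bears on why these numbers differ.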